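A few compounds are considered here, and "the series" means these few. Any claim that something is new, unique, unknown or untested is made for them only; others in the source may bear on it.

Measured in a functional assay on U-87MG ATCC cells for cytotoxicity against U-87 MG (Homo sapiens), read by colorimetric assay and MTT assay; on this read-out lower numbers stand for stronger inhibition and higher numbers for weaker inhibition:
- compound 1 `COc1cc(OC)c2cc(-c3ccccc3)c(O)nc2c1`: 10000 nM
- compound 2 `CCOC(=O)Cn1c(=O)c(-c2ccc(OC)cc2)cc2c(OC)cc(OC)cc21`: 10000 nM
- compound 3 `COc1ccc(-c2cc3c(OC)cc(OC)cc3n(CC#N)c2=O)cc1`: 10000 nM

Compound 3 stands level with compound 1 and compound 2 on these numbers. Next is compound 4 `COc1ccc(-c2cc3c(OC)cc(OC)cc3n(CC(=O)OCc3ccccc3)c2=O)cc1`, with benzyloxycarbonyl in place of cyano on a saturated chain carbon bound to an aromatic nitrogen. Going by the values given here, one measured step bears on this place, no change at the digits printed from compound 2 to compound 3 (within the scatter), and it exchanged ethoxycarbonyl for cyano. Among the compounds with values here, no measured step tests the aromatic ring that enters with benzyloxycarbonyl, so some room is left toward stronger inhibition. No step beyond the scatter is expected in this assay. The expected step is no change at the digits printed from compound 3 to compound 4 (within the scatter). For compound 4 the estimated value is 10000 nM, within an expected range of 4000 nM to 12000 nM.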

Compound 4, half-maximal inhibitory concentration: 10000 nM
Compound 4: the middle estimate sits on the measured number at the digits printed; low and high end bracket the measured number.
By their numbers in this assay, from the lowest: compounds 1, 2, 3 and 4 (each within the scatter of the next).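

In this assay, adding the aromatic ring that enters with benzyloxycarbonyl on a saturated chain carbon bound to an aromatic nitrogen gives no change at the digits printed from compound 3 to compound 4 (within the scatter) and so extends the flat reading beyond the earlier ethoxycarbonyl-to-cyano exchange. Phenyl in place of methyl on a saturated chain carbon bound to an oxygen next to a carbonyl group gives no change at the digits printed from compound 2 to compound 4 (within the scatter) within the ester itself. No measured evidence accounts for this flat result.

As far as these compounds go, an amine or a carboxylic acid on this chain remains open. Also open, from the compounds shown here alone, is whether any group at this place can separate from compound 4 at 10000 nM in this assay.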